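Swapping the amide substituent on a shared spiro core

A few compounds are considered here, and "the series" means these few. Any claim that something is new, unique, unknown or untested is made for them only; others in the source may bear on it.

Compound 3 `CCOC(=O)C1CCN(C(=O)CN2CN(c3ccccc3)C3(CCN(C(=O)c4ccc(C(C)(C)C)cc4)CC3)C2=O)CC1` is measured in an assay on HEK293 cells for displacement of a labelled ligand from NPC1-like intracellular cholesterol transporter 1 (Homo sapiens) (a lower number here means a stronger inhibitor, a higher number a weaker inhibitor), where compound 3 gives 3100 nM. Going by the values given here, of the two numbers recorded it is the lowest: compound 1 `CC(C)(C)c1ccc(C(=O)N2CCC3(CC2)C(=O)N(CC(=O)N2CCN(S(C)(=O)=O)CC2)CN3c2ccccc2)cc1` gives 19000 nM in this assay, and the step of a 6.1-fold lower number from compound 1 to compound 3 (0.79 log units; beyond the scatter) is the only measured step to draw on. For compound 2 `COC(=O)CCCNC(=O)CN1CN(c2ccccc2)C2(CCN(C(=O)c3ccc(C(C)(C)C)cc3)CC2)C1=O` this assay records "not determined" (no result reported), so no number is available for it. Compound 4 `CC(C)(C)c1ccc(C(=O)N2CCC3(CC2)C(=O)N(CC(=O)N2CCCCC2CO)CN3c2ccccc2)cc1` differs from compound 3 by 2-(hydroxymethyl)piperidin-1-yl in place of 4-(ethoxycarbonyl)piperidin-1-yl on a carbonyl carbon. Among the compounds with values here, the single measured step at this carbonyl carbon shows that exchanging the group there can shift the number well beyond the scatter, yet it does not reveal which direction a hydroxymethyl-bearing ring will take. Compound 4 is therefore expected to lie near 6000 nM, with a range from 1500 nM to 25000 nM, an expected step of a 1.9-fold higher number from compound 3 to compound 4 (0.29 log units; within the scatter) that stays within the scatter but with wide uncertainty.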

Compound 4, half-maximal inhibitory concentration: 11800 nM
Compound 4: middle estimate off by 2.0-fold (0.29 log units), on the low side; measured number inside the range.
By their numbers in this assay, from the lowest: compound 3; then compounds 4 and 1 (each within the scatter of the next).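

In this assay the change to 2-(hydroxymethyl)piperidin-1-yl on this carbonyl carbon gives a 3.8-fold higher number from compound 3 to compound 4 (0.58 log units; beyond the scatter), so keeping a piperidine ring here does not by itself keep the lowest number. Against 4-(methylsulfonyl)piperazin-1-yl the same group gives a 1.6-fold lower number from compound 1 to compound 4 (0.21 log units; within the scatter), so these two groups cannot be told apart in this assay, and among the three measured compounds only 4-(ethoxycarbonyl)piperidin-1-yl stands apart. No measurement here accounts for this difference. Still open, going by these compounds, is whether the ethyl ester itself matters or its place on the ring, which a 4-(hydroxymethyl)piperidin-1-yl or 4-carboxypiperidin-1-yl group on this carbonyl carbon could help to separate.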